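Notes on compound 4: thiophen-2-yl for 4-methylphenyl

The source may hold more compounds than are shown below. What is called first, only, known or untested is meant among the compounds shown, and "the series" means these compounds.

Measured so far in a functional assay on HepG2 cells (Homo sapiens) for cytotoxicity, read by MTT assay, with a stated time of 72 h; on this read-out higher numbers stand for weaker inhibition and lower numbers for stronger inhibition:
compound 1 `COc1ccc2ccc(=O)oc2c1C1=NNC(c2ccc(C)cc2)C1`, 43 nM
compound 2 `COc1ccc2ccc(=O)oc2c1C1=NNC(c2ccc(C(F)(F)F)cc2)C1`, 13 nM
compound 3 `COc1ccc2ccc(=O)oc2c1C1=NN(c2ccccc2)C(c2ccc(C)cc2)C1`, 51 nM

Compound 1 stands second highest of the three numbers. Its nearest neighbour is compound 3, with a 1.2-fold higher number from compound 1 to compound 3 (0.07 log units; within the scatter); the furthest is compound 2, with a 3.3-fold lower number from compound 1 to compound 2 (0.52 log units; beyond the scatter).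

Compound 4 `COc1ccc2ccc(=O)oc2c1C1=NNC(c2cccs2)C1` differs from compound 1 by thiophen-2-yl in place of 4-methylphenyl on a saturated ring carbon. Going by the values given here, no measured step exchanges the whole group on that saturated ring carbon. The step from compound 1 to compound 2 alters only a substituent on the same aryl group and is modest; the step from compound 1 to compound 3 sits elsewhere and is within the scatter. Among the compounds with values here, the series therefore gives no direct precedent for this exchange, and the expected step in this assay is small, a 1.1-fold lower number from compound 1 to compound 4 (0.03 log units; within the scatter), with wide uncertainty. Compound 4 is estimated at 40 nM, range 14 nM to 115 nM.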

Compound 4, half-maximal inhibitory concentration: 11 nM
For compound 4 the middle estimate is 3.6-fold (0.56 log units) above the measured one, outside the stated range (below it).
By their numbers in this assay, from the lowest: compounds 4 and 2 (each within the scatter of the next); then compounds 1 and 3 (each within the scatter of the next).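

In this assay, exchanging the whole group on the saturated ring carbon gives a 3.9-fold lower number from compound 1 to compound 4 (0.59 log units; beyond the scatter), so this position responds to a change of the ring itself and not only to a substituent on the 4-methylphenyl group. Compound 4 and compound 2 lie within the scatter of each other, so thiophen-2-yl and the trifluoromethyl-bearing aryl group reach the same level. No measurement available accounts for this step.

Open, going by these compounds, is whether furan-2-yl or pyridinyl at this carbon behaves like thiophen-2-yl. Also open, on these data alone, is whether thiophen-2-yl keeps its effect with phenyl on the ring nitrogen.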